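The source may report more compounds than this note shows. Statements on the series, on what has been measured and on what is new or still open speak of the compounds shown alone.

Among the three compounds measured so far, compound 3 `O=C(NCc1cccs1)C1=C(c2ccc(Cl)c(Cl)c2)CCC1` stands lowest in an assay on COS-1 cells for displacement of a labelled ligand from sodium-dependent dopamine transporter (Homo sapiens) (on this read-out higher numbers stand for weaker inhibition and lower numbers for stronger inhibition), at 140 nM. Compound 1 `O=C(C1=C(c2ccc(Cl)c(Cl)c2)CCC1)N1CCCC1` gives 58000 nM in this assay, and compound 2 `CCN(CC)C(=O)C1=C(c2ccc(Cl)c(Cl)c2)CCC1` gives 94000 nM. The step from compound 3 to compound 4 `CC(C)OC(=O)C1=C(c2ccc(Cl)c(Cl)c2)CCC1` changes (isopropoxy in place of ((thiophen-2-yl)methyl)amino on a carbonyl carbon). Among the compounds with values here, two measured steps bear on it, both running the opposite way: a 410-fold lower number from compound 1 to compound 3 (2.62 log units; beyond the scatter) and a 670-fold lower number from compound 2 to compound 3 (2.83 log units; beyond the scatter). In each, the ((thiophen-2-yl)methyl)amino group entered and the number fell by a large amount, so the group that now leaves compound 3 is the one that accompanied the lowest number in the series. Within the data shown here, no measured pair shows an isopropoxy group or any ester on the carbonyl carbon, so the exact size of the step is open. The step is nevertheless expected to be large and upward, toward weaker inhibition, at a 140-fold higher number from compound 3 to compound 4 (2.15 log units; beyond the scatter). Compound 4 is estimated at 20000 nM, with a range from 3000 nM to 150000 nM.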

Compound 4, inhibition constant: 2600 nM
Estimate against measurement, compound 4: 7.7-fold (0.89 log units) above, and the stated range ends above it.
By their numbers in this assay, from the lowest: compound 3; then compound 4; then compounds 1 and 2 (each within the scatter of the next).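

At this position on the carbonyl carbon, this assay now shows three levels instead of two: isopropoxy loses ground against ((thiophen-2-yl)methyl)amino, with a 19-fold higher number from compound 3 to compound 4 (1.27 log units; beyond the scatter), yet gains on the other two groups, with a 36-fold lower number from compound 2 to compound 4 (1.56 log units; beyond the scatter) and a 22-fold lower number from compound 1 to compound 4 (1.35 log units; beyond the scatter). Removing the ((thiophen-2-yl)methyl)amino group therefore need not return the number to the level of compound 1 and compound 2, so that group is not the only one on this carbonyl carbon to lower the number. Nothing measured on these compounds accounts for the three levels.

The compounds shown leave open whether the thiophene ring or the amide hydrogen goes with the lowest number, which a benzylamino or isopropylamino group could help separate. On these data alone, how a methoxy group or a carboxylic acid would stand at this position also remains open.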